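The compounds below may be only part of what the source reports. "The series", "measured", "known", "first", "only" and "open" are said of these compounds alone.

In an ADME assay on microsomes from liver (Mus musculus) for metabolic stability, with a stated time of 10 min (a higher number here means that more of the compound is left, a lower number that less of the compound is left), compound 1 `C[C@]1(C(=O)O)CC[C@H](C(=O)N2CC[C@](c3ccc(C(F)(C(F)(F)F)C(F)(F)F)cc3)(S(=O)(=O)c3ccc(F)cc3)C2)CC1` gives 93%, compound 2 `C[C@]1(C(=O)N2CC[C@](c3ccc(C(F)(C(F)(F)F)C(F)(F)F)cc3)(S(=O)(=O)c3ccc(F)cc3)C2)CC[C@H](C(=O)O)CC1` gives 95% and compound 3 `COC[C@]1(C(=O)N2CC[C@](c3ccc(C(F)(C(F)(F)F)C(F)(F)F)cc3)(S(=O)(=O)c3ccc(F)cc3)C2)CC[C@H](C(=O)O)CC1` gives 88%. Compound 3 therefore stands level with the other two, all within the usual scatter. Compound 4 `O=C(O)C12CCC(C(=O)N3CC[C@](c4ccc(C(F)(C(F)(F)F)C(F)(F)F)cc4)(S(=O)(=O)c4ccc(F)cc4)C3)(CC1)OC2` alters the same group of compound 3, on a carbonyl carbon: a group of 11 heavy atoms (8 carbon, 3 oxygen; one six-membered non-aromatic ring of carbon only, one six-membered non-aromatic ring with 1 hetero atom) in place of a group of 12 heavy atoms (9 carbon, 3 oxygen; one six-membered non-aromatic ring of carbon only), on a carbonyl carbon. For the measured compounds named here, three measured steps touch this group: a number 2 percentage points higher from compound 1 to compound 2 (within the scatter), a number 5 percentage points lower from compound 1 to compound 3 (within the scatter) and a number 7 percentage points lower from compound 2 to compound 3 (within the scatter). All three stay within the scatter, although none of them introduces the six-membered ring with 1 hetero atom, so the evidence is only indirect. The expected step is a number 2 percentage points higher from compound 3 to compound 4 (within the scatter), with no shift beyond the scatter anticipated. For compound 4 the estimated value is 90%, within an expected range of 78% to 98%.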

Compound 4, percent of the compound remaining: 94%
The estimate for compound 4 lay 4 percentage points below the measured number, and the stated range covers the measured number.
By their numbers in this assay, from the lowest: compounds 3, 1, 4 and 2 (each within the scatter of the next).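

In this assay, the new group is the only one of the four to carry a six-membered ring with 1 hetero atom, and the read-out stays level with a number 6 percentage points higher from compound 3 to compound 4 (within the scatter) and a number 1 percentage points lower from compound 2 to compound 4 (within the scatter) and a number 1 percentage points higher from compound 1 to compound 4 (within the scatter). On this carbonyl carbon, then, that ring is accepted without a change beyond the scatter. Nothing here offers an explanation for this result. On these data alone, all four groups carry a carboxylic acid, so what an amine in its stead would do stays open, as does whether any group on this carbon can shift the number beyond the scatter.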